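Taking the chloro group off compound 3

The source may report more compounds than this note shows. Statements on the series, on what has been measured and on what is new or still open speak of the compounds shown alone.

In a functional assay on the whole organism for inhibition, with Scenedesmus acutus as the target (on this read-out higher numbers stand for weaker inhibition and lower numbers for stronger inhibition), compound 3 `S=c1s/c(=N\c2ccc(Cl)cc2)n2n1CCCC2` gives 339 nM. Compound 1 `Cc1cc(Cl)ccc1/N=c1\sc(=S)n2n1CCCC2` gives 457 nM, and compound 2 `S=c1s/c(=N\c2ccc(Br)cc2)n2n1CCCC2` gives 162 nM, so compound 3 stands close to compound 1 and apart from compound 2. Compound 4 `S=c1s/c(=N\c2ccccc2)n2n1CCCC2` has not been measured yet. It differs from compound 3 by one small edit: hydrogen in place of chloro on an aromatic carbon. This puts hydrogen in place of chloro on an aromatic carbon, para to a large group.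

Going by the values given here, two measured steps bear on this edit. The closer one swaps bromo for chloro at the same place and gives a 2.1-fold higher number from compound 2 to compound 3 (0.32 log units; beyond the scatter), a modest loss of strength. The other swaps methyl for hydrogen and gives a 1.3-fold lower number from compound 1 to compound 3 (0.13 log units; within the scatter), but it removes a different group. With only these two steps as a guide, a further modest rise in this assay is expected, though the evidence is thin. The expected change is a 2.1-fold higher number from compound 3 to compound 4 (0.31 log units; beyond the scatter). Compound 4 is estimated at 700 nM, with an expected range from 280 nM to 1800 nM.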

Compound 4, half-maximal inhibitory concentration: 14100 nM
Compound 4: the middle estimate sits 20-fold (1.30 log units) below what was measured; measured number outside the range, above it.
By their numbers in this assay, from the lowest: compound 2; then compounds 3 and 1 (each within the scatter of the next); then compound 4.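

In this assay, going by these compounds alone, this place on the aromatic ring, para to a large group, proves far more sensitive than the earlier compounds suggested: replacing chloro with hydrogen gives a 42-fold higher number from compound 3 to compound 4 (1.62 log units; beyond the scatter), and replacing bromo with hydrogen gives an 87-fold higher number from compound 2 to compound 4 (1.94 log units; beyond the scatter). Among these compounds, the choice between a halogen and hydrogen here therefore matters much more than the choice between bromo and chloro, since the step between those two halogens was modest. What lies behind this large loss of strength cannot be said from the information available.

Going by these compounds, it remains open whether other groups at this place, such as fluoro, methoxy, nitrile or an amine, would match the halogens or fall towards compound 4. On these data alone, it is also open whether taking the chloro group off compound 1, which also carries a methyl group, would have an equally large effect.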